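The source may hold more compounds than are shown below. What is called first, only, known or untested is meant among the compounds shown, and "the series" means these compounds.

Compound 1 `O=C1C(N2CCCCC2)=CC(=O)c2c1nc1n2[C@H]2OC[C@@H](O)[C@H]2OC1`: in a functional assay on MCF7 cells (Homo sapiens) for inhibition, read by sulforhodamine B assay (a lower number here means a stronger inhibitor, a higher number a weaker inhibitor), compound 1 gives only a limit, > 8000 nM.
Compound 2 `O=C1C(Nc2ccccc2)=CC(=O)c2c1nc1n2[C@H]2OC[C@@H](O)[C@H]2OC1`: in this assay compound 2 gives only a limit, > 4000 nM.
Compound 3 `O=C1C(Nc2ccc(C(F)(F)F)cc2)=CC(=O)c2c1nc1n2[C@H]2OC[C@@H](O)[C@H]2OC1`: in this assay compound 3 gives only a limit, > 4000 nM.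

Compound 3 therefore stands at a limit and not at a number, and the same holds for the two other values shown, which sit at the limit of > 4000 nM in this assay, at which 2 of the 3 values shown sit, and (the limit of > 8000 nM in this assay, at which 1 of the 3 values shown sits). Neither measured step can be sized: the step that the two limits leave unreadable from compound 1 to compound 2 and the step that the two limits leave unreadable from compound 2 to compound 3 both lie between limits.

Compound 4 `O=C1C(Nc2cccc(F)c2)=CC(=O)c2c1nc1n2[C@H]2OC[C@@H](O)[C@H]2OC1` differs from compound 3 by 3-fluorophenyl in place of 4-(trifluoromethyl)phenyl on an amine nitrogen. The step from compound 2 to compound 3, which also changes a substituent on the same aromatic ring, is the only one that bears on this change, and its size is not readable. With no readable step to build on, compound 4 is expected to give a limit again, so the step that the limit leaves unreadable from compound 3 to compound 4 is estimated to be no larger than the usual scatter. On that basis compound 4 is estimated at 6000 nM, within 2000 nM to 20000 nM.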

Compound 4, half-maximal inhibitory concentration: > 4000 nM
Compound 4 gave a limit, no number; the forecaster's own chance of this, stated with the estimate: 80%; the middle value lies beyond the limit too.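

In this assay compound 4 gives only a limit, > 4000 nM, so the steps to it from compound 1, compound 2 and compound 3 cannot be read. The compounds shown leave open how strongly any of these four inhibits, and whether any of these substituent changes alters that.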